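This account rests on a few compounds, and the source may have more. Where it says the series, first, only, none or still open, it means among the compounds named here.

Measured compounds:
- Compound 1 `Cc1nn([C@H](C)c2ccc(Cl)cc2Cl)c2nc(N3CC[C@H](N4CCC[C@H]4C(N)=O)[C@H](C)C3)cnc12`: 170 nM
- Compound 2 `CC1CN(c2cnc3c(C#N)nn(C(C)c4ccc(Cl)cc4Cl)c3n2)CCC1N1CCCCC1`: 251 nM

Of the compounds shown here, two have been measured in a functional assay on cells for antagonist activity at C-C chemokine receptor type 4 (Homo sapiens), read by fluorescence and calcium flux, with stated times of 2.5 s and 45 s; on this read-out higher numbers stand for weaker inhibition and lower numbers for stronger inhibition. Compound 1 gives 170 nM in this assay, and compound 2 gives 251 nM. Compound 1 has the lower of the two numbers, but the gap to compound 2 lies within the usual scatter of repeated measurements, so the two cannot be told apart on these data alone.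

Compound 3 `Cc1nn([C@H](C)c2ccc(Cl)cc2Cl)c2nc(N3CC[C@H](N4CCC[C@H]4CO)[C@H](C)C3)cnc12` has not yet been measured. It is built from compound 1 by a single change: hydroxymethyl in place of carbamoyl on a saturated ring carbon. Both the group that leaves and the group that enters carry one hydrogen-bond donor and one hydrogen-bond acceptor, and the change sits on a saturated ring carbon of the five-membered non-aromatic ring. For the measured compounds named here, no measured pair shows this kind of exchange, so there is no direct guide to the size of the step. The expectation is a small shift, if any, from compound 1 to compound 3 in this assay, not clearly beyond the scatter, with slightly weaker inhibition somewhat more likely than stronger: a 1.5-fold higher number from compound 1 to compound 3 (0.17 log units; within the scatter). Compound 3 is therefore estimated at 250 nM in this assay, with a likely range from 80 nM to 800 nM.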

Compound 3, half-maximal inhibitory concentration: 32 nM
Compound 3: middle estimate off by 7.8-fold (0.89 log units), on the high side, and the stated range ends above it.
By their numbers in this assay, from the lowest: compound 3; then compounds 1 and 2 (each within the scatter of the next).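

In this assay, hydroxymethyl in place of carbamoyl on the saturated ring carbon gives a 5.3-fold lower number from compound 1 to compound 3 (0.73 log units; beyond the scatter), a step beyond the scatter. This shows that the group at this place, on the five-membered ring and next to the ring nitrogen, matters to the read-out: the carbamoyl with its 3 heavy atoms and the hydroxymethyl with its 2 have the same count of hydrogen-bond donors and acceptors, yet their numbers clearly differ, which means that this count alone does not predict the outcome for this pair. No measurement at hand speaks to why the step has this size or direction.

Still open, on these data alone, is how other groups on this carbon would compare with hydroxymethyl, for example methoxymethyl, aminomethyl, a plain methyl or a carboxylic acid, and whether a longer chain such as hydroxyethyl would give a higher or lower number. Also open, as far as these compounds go, is whether the same exchange would give a step of similar size on a compound carrying the nitrile seen in compound 2.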